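Swapping the Imidazole Arm for a Triazolylamino Arm

The compounds below may be only part of what the source reports. "The series", "measured", "known", "first", "only" and "open" are said of these compounds alone.

Of the compounds shown here, three sharing one core have been measured in an assay on CHO cells for displacement of a labelled ligand from prostaglandin E2 receptor EP3 subtype (Homo sapiens), read by radioligand binding; a lower number here means a stronger inhibitor, a higher number a weaker inhibitor. Compound 1 `CC(C)C(c1ncc[nH]1)c1ccc(-c2ccc3cccc(F)c3c2)[nH]c1=O` gives 7.3 nM. Compound 2 `CC(C)C(c1ccc(-c2ccc3cccc(F)c3c2)[nH]c1=O)N1CCCCC1=O` gives 6.4 nM, and compound 3 `CC(C)C(Nc1nccs1)c1ccc(-c2ccc3cccc(F)c3c2)[nH]c1=O` gives 9.4 nM. Compound 1 stands second highest of the three numbers, with a 1.1-fold lower number from compound 1 to compound 2 (0.06 log units; within the scatter) and a 1.3-fold higher number from compound 1 to compound 3 (0.11 log units; within the scatter); neither of these, nor a 1.5-fold higher number from compound 2 to compound 3 (0.17 log units; within the scatter), reaches beyond the scatter. Compound 4 `CC(C)C(Nc1nnc[nH]1)c1ccc(-c2ccc3cccc(F)c3c2)[nH]c1=O` differs from compound 1 by (4H-1,2,4-triazol-3-yl)amino in place of 1H-imidazol-2-yl on a saturated chain carbon bound to an aromatic carbon and a saturated chain carbon. The step that bears most on this, the (1,3-thiazol-2-yl)amino replacement seen in a 1.3-fold higher number from compound 1 to compound 3 (0.11 log units; within the scatter), stayed within the scatter. A step within the scatter is therefore expected in this assay, with no clear direction, a 1.2-fold higher number from compound 1 to compound 4 (0.09 log units; within the scatter). The estimate for compound 4 is 9 nM, with a range from 4 nM to 22 nM.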

Compound 4, inhibition constant: 22 nM
Estimate against measurement, compound 4: 2.4-fold (0.39 log units) below; the range from low to high includes it.
By their numbers in this assay, from the lowest: compounds 2, 1 and 3 (each within the scatter of the next); then compound 4.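

Of the four arms on this saturated chain carbon, only the (4H-1,2,4-triazol-3-yl)amino arm stands apart, weaker than the 1H-imidazol-2-yl arm (a 3.0-fold higher number from compound 1 to compound 4 (0.48 log units; beyond the scatter)) and the 2-oxopiperidin-1-yl arm (a 3.4-fold higher number from compound 2 to compound 4 (0.54 log units; beyond the scatter)). The amine link alone does not account for this, since exchanging only 1,3-thiazol-2-yl for 4H-1,2,4-triazol-3-yl on the amine nitrogen also gives a step beyond the scatter (a 2.3-fold higher number from compound 3 to compound 4 (0.37 log units; beyond the scatter)). Nothing measured here explains the change. Still open, on these data alone, is whether a 1,2,4-triazole joined directly to the chain carbon, without the amine nitrogen, or a pyridin-2-ylamino arm would match compound 1.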